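A few compounds are considered here, and "the series" means these few. Any claim that something is new, unique, unknown or untested is made for them only; others in the source may bear on it.

Measured so far:
Compound 1 `CCn1cc(C(CC)(CC)c2ccc(C#CC(O)(CC)CC)c(C)c2)cc1C(=O)NCCN(C)C`, 19.3 nM
Compound 2 `CCn1cc(C(CC)(CC)c2ccc(C#CC(O)(CC)CC)c(C)c2)cc1C(=O)NCCCN(C)C`, 142 nM
Compound 3 `CCCCC(=O)c1cc(C(CC)(CC)c2ccc(C#CC(O)(CC)CC)c(C)c2)cn1CC`, > 50 nM

These values come from an assay on cells for agonist activity at vitamin D3 receptor (Homo sapiens), read by microscopy; a higher number here means that more compound is needed for the effect, a lower number that less compound is needed. For compound 3 the assay gives no number, only a limit, > 50 nM, which is the limit noted as the limit of > 50 nM in this assay, at which 1 of the 3 values shown sits. Compound 3 therefore stands at the weak end of the three, without a known position beyond that.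

Compound 4 `CCn1cc(C(CC)(CC)c2ccc(C#CC(O)(CC)CC)c(C)c2)cc1C(=O)N[C@H](C(=O)O)C(C)C` differs from compound 3 at the carbonyl carbon attached to the shared core: (1-carboxy-2-methylpropyl)amino in place of butyl on a carbonyl carbon. The closest measured steps are those that change the same carbonyl substituent. From compound 1 to compound 3 the step was an at least 2.5-fold higher number from compound 1 to compound 3 (0.41 log units; beyond the scatter), so replacing an amide-linked chain by butyl cost potency. From compound 2 to compound 3 the step was a step that the limit leaves unreadable from compound 2 to compound 3. Compound 4 restores an amide-linked substituent, but one carrying a carboxylic acid rather than a dimethylamino group, so the measured steps bear on it only loosely.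

The step from compound 3 to compound 4 in this assay is estimated as a step that the limit leaves unreadable from compound 3 to compound 4, with the limit on compound 3 making its size uncertain. Compound 4 is expected to give about 60 nM, within a range from 15 nM to 250 nM.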

Compound 4, half-maximal effective concentration: 12.7 nM
Compound 4: middle estimate off by 4.7-fold (0.67 log units), on the high side, and the stated range ends above it.
By their numbers in this assay, from the lowest: compounds 4 and 1 (each within the scatter of the next); then compound 2.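

Up to this point, every amide on this carbonyl carbon ended in a dimethylamino group, yet in this assay an amide carrying a carboxylic acid serves as well as the shorter of those chains, with a 1.5-fold lower number from compound 1 to compound 4 (0.18 log units; within the scatter). Against the longer chain the same group gives an 11-fold lower number from compound 2 to compound 4 (1.05 log units; beyond the scatter), so what sits on the amide-type nitrogen clearly matters, and a dimethylamino end is not needed for a low number in this set. Putting (1-carboxy-2-methylpropyl)amino in place of butyl gives an at least 3.9-fold lower number from compound 3 to compound 4 (0.59 log units; beyond the scatter), a size that rests on a limit and not on a measured number: the limit of > 50 nM in this assay, at which 1 of the 4 values shown sits.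

The compounds shown do not separate the contribution of the carboxylic acid from that of the branched carbon chain within the same group. How a methyl ester in place of the carboxylic acid, or the opposite configuration at the defined stereocentre, would read in this assay remains an open question.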